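Solubility of a pyrazole sulfonamide series: a piperidinyl amide

A few compounds are considered here, and "the series" means these few. Any claim that something is new, unique, unknown or untested is made for them only; others in the source may bear on it.

Measured compounds:
compound 1 `CCC(=O)c1cc(-c2ccc(S(N)(=O)=O)cc2)n(-c2ccc(Cl)cc2)n1` — 41900 nM
compound 2 `CCC(=O)c1cc(-c2ccc(S(N)(=O)=O)cc2)n(-c2ccccc2Cl)n1` — 4700 nM
compound 3 `CCC(=O)c1cc(-c2ccc(S(N)(=O)=O)cc2)n(-c2ccccc2)n1` — 47200 nM

Of the compounds shown here, three sharing one core have been measured in a physicochemical assay for solubility, read by HPLC, in phosphate buffer, measured as kinetic solubility, at pH 7.4; on this read-out lower numbers stand for lower solubility and higher numbers for higher solubility. Compound 1 gives 41900 nM and stands second highest of the three. Its nearest neighbour is compound 3, with a change that stays within the scatter (a 1.1-fold higher number from compound 1 to compound 3 (0.05 log units; within the scatter)), while the largest gap separates it from compound 2 (an 8.9-fold lower number from compound 1 to compound 2 (0.95 log units; beyond the scatter)). The step from compound 2 to compound 3 is of similar size (a 10-fold higher number from compound 2 to compound 3 (1.00 log units; beyond the scatter)). Both steps beyond the scatter concern the chloro on the aromatic ring attached to the ring nitrogen.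

Compound 4 `NS(=O)(=O)c1ccc(-c2cc(C(=O)N3CCCCC3)nn2-c2ccc(Cl)cc2)cc1` differs from compound 1 elsewhere: piperidin-1-yl in place of ethyl on a carbonyl carbon. Going by the values given here, none of the measured steps touches this carbonyl position, so no measured step bears directly on the change. The expectation therefore rests on the value of compound 1 alone, with widened uncertainty. Compound 4 is expected to give a number close to that of compound 1, with a step of a 1.4-fold lower number from compound 1 to compound 4 (0.15 log units; within the scatter), which is not beyond the scatter. The estimate for compound 4 in this assay is 30000 nM, with a range from 9000 nM to 100000 nM.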

Compound 4, solubility: 65900 nM
Beside the measured number, compound 4's estimate is 2.2-fold (0.34 log units) below it; the range from low to high includes it.
By their numbers in this assay, from the lowest: compound 2; then compounds 1, 3 and 4 (each within the scatter of the next).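

Going by these compounds alone, with the carbonyl position now touched for the first time, the change from ethyl to piperidin-1-yl on a carbonyl carbon, which brings in a six-membered non-aromatic ring with a nitrogen, gives in this assay a step that stays within the scatter (a 1.6-fold higher number from compound 1 to compound 4 (0.20 log units; within the scatter)). This position of the core of compound 1 therefore accepts this exchange with no measurable change in the read-out, whereas moving the chloro on the ring attached to the aromatic nitrogen gives a step beyond the scatter (an 8.9-fold lower number from compound 1 to compound 2 (0.95 log units; beyond the scatter)). Nothing in the data given accounts for the outcome at the carbonyl carbon.

Going by these compounds, this is a single exchange on a single background, so it remains open whether morpholin-4-yl, a dimethylamino group or a carboxylic acid at the same carbonyl carbon would also stay within the scatter of compound 1. On these data alone, it also remains open whether piperidin-1-yl would leave the number similarly unmoved on the 2-chlorophenyl background of compound 2, which gives the lowest number of the series in this assay.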